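Bromo to methyl on compound 2

The compounds below may be only part of what the source reports. "The series", "measured", "known", "first", "only" and "open" are said of these compounds alone.

In a functional assay on DU-145 cells (Homo sapiens) for inhibition, read by trypan blue exclusion, with a stated time of 96 h (a higher number here means a weaker inhibitor of growth, a lower number a stronger inhibitor of growth), compound 2 `Cc1cc(C)cc(/C=C(\C(=O)c2ccc(Cl)cc2)S(=O)(=O)c2ccc(Br)cc2)c1` gives 10000 nM. Compound 1 `Cc1ccc(S(=O)(=O)/C(=C/c2sccc2C)C(=O)c2ccc(Cl)cc2)cc1`, which carries 4-methylphenyl, gives 10000 nM, level with compound 2 within the scatter. Compound 3 `O=C(/C(=C\c1c(O)cc(O)cc1O)S(=O)(=O)c1ccc(Br)cc1)c1ccc(Cl)cc1` reads > 100000 nM, which is a limit of the assay and not a number. Going by the values given here, the only measured step, an at least 10-fold higher number from compound 2 to compound 3 (1.00 log units; beyond the scatter), puts 2,4,6-trihydroxyphenyl in place of 3,5-dimethylphenyl. It lies at another place and gives no size for the present change. Compound 4 `Cc1ccc(S(=O)(=O)/C(=C/c2cc(C)cc(C)c2)C(=O)c2ccc(Cl)cc2)cc1` differs from compound 2 by methyl in place of bromo on an aromatic carbon, para to a large group. No step beyond the scatter is expected in this assay, given 4-methylphenyl in compound 1 at 10000 nM. The expected step is no change at the digits printed from compound 2 to compound 4 (within the scatter). Compound 4 is estimated at 10000 nM, within 3000 nM to 30000 nM.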

Compound 4, concentration for 50% growth inhibition: 1000 nM
Compound 4: the middle estimate sits 10-fold (1.00 log units) above what was measured; measured number below the stated range.
By their numbers in this assay, from the lowest: compound 4; then compounds 1 and 2 (each within the scatter of the next). At a limit, above all of these: compound 3.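

In this assay, the change from 4-bromophenyl to 4-methylphenyl is not silent in this series (a 10-fold lower number from compound 2 to compound 4 (1.00 log units; beyond the scatter)). The other place also counts with 4-methylphenyl held constant (a 10-fold lower number from compound 1 to compound 4 (1.00 log units; beyond the scatter)), so the level readings of compound 1 and compound 2 did not mean that this position was indifferent. Nothing shown gives a reason for the step.

As far as these compounds go, what an amine or a carboxylic acid would do on this aromatic carbon stays open. Also open, from the compounds shown here alone, is whether the bromo to methyl step carries over to compounds with 3-methylthiophen-2-yl.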